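Compound 2 to compound 3: a change on the carbonyl carbon

The compounds below may be only part of what the source reports. "The series", "measured", "known", "first", "only" and "open" are said of these compounds alone.

- Compound 1 `C#CCCOC(=O)c1ccc(C(CC)(CC)c2ccc(OCCC(O)(CC)CC)c(C)c2)n1CC`: > 50000 nM (a limit)
- Compound 2 `CCn1c(C(=O)N(C)CCO)ccc1C(CC)(CC)c1ccc(OCCC(O)(CC)CC)c(C)c1`: 74 nM

The series has been read in a functional assay on Caco-2 cells (Homo sapiens) for antiproliferative activity, read by MTT assay, with a stated time of 48 h; a lower number here means a stronger inhibitor, a higher number a weaker inhibitor. Among the compounds with values here, there, compound 2 gives 74 nM, the only actual number so far. Compound 1 gives > 50000 nM, which is a limit of the assay and not a number.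

Compound 3 `CCn1c(C(=O)NC(CO)CCO)ccc1C(CC)(CC)c1ccc(OCCC(O)(CC)CC)c(C)c1` keeps the core of compound 2 and differs in one place: a group of 7 heavy atoms (4 carbon, 1 nitrogen, 2 oxygen; no ring) in place of a group of 5 heavy atoms (3 carbon, 1 nitrogen, 1 oxygen; no ring), on a carbonyl carbon. Within the data shown here, the single measured step touches the same carbonyl carbon: an at least 670-fold lower number from compound 1 to compound 2 (2.82 log units; beyond the scatter). On these data alone, that step is large, but one end of it is a limit, so its true size is unknown. It also replaces a different group, (but-3-yn-1-yl)oxy, and offers no direct measure of the present change. With compound 2 at 74 nM as the only anchor, the expectation is a modest move towards a higher number, with the opposite direction not excluded. The expected step is a 2.0-fold higher number from compound 2 to compound 3 (0.31 log units; beyond the scatter). For compound 3 the estimated value is 150 nM, with an expected range of 25 nM to 900 nM.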

Compound 3, half-maximal inhibitory concentration: 40200 nM
Beside the measured number, compound 3's estimate is 270-fold (2.43 log units) below it; measured number outside the range, above it.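

In this assay, the change on the carbonyl carbon gives a 540-fold higher number from compound 2 to compound 3 (2.73 log units; beyond the scatter). A nitrogen-linked group at this carbon therefore does not by itself carry the low number seen before. The earlier step set (2-hydroxyethyl)(methyl)amino against (but-3-yn-1-yl)oxy; this one shows that, with the shared core unchanged, the read-out also turns on which hydroxyl-bearing group sits on the nitrogen. The other new step is an at least 1.2-fold lower number from compound 1 to compound 3 (0.09 log units; that floor lies within the scatter). Its true size cannot be read, because one end of it is a limit and not a number: the limit of > 50000 nM in this assay, at which 1 of the 3 values shown sits.

The entering group differs from (2-hydroxyethyl)(methyl)amino in several features at once, losing the methyl on nitrogen, gaining the amide hydrogen and adding a branch with a further hydroxyl, and the compounds shown do not separate these. On these data alone, it remains open whether the plain (2-hydroxyethyl)amino group would keep the number of compound 2 or follow compound 3, and whether a dimethylamino group, with no hydroxyl at all, would hold up at this carbonyl carbon.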